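A few compounds are considered here, and "the series" means these few. Any claim that something is new, unique, unknown or untested is made for them only; others in the source may bear on it.

Of the compounds shown here, three that share one core have been measured in a functional assay on CHO cells with adenosine receptor A1 (Homo sapiens) as the target, read by cAMP accumulation and immunoassay, with a stated time of 6 min, tested at 0.1 uM; on this read-out lower numbers stand for a stronger effect and higher numbers for a weaker effect at the one concentration tested. Compound 1 `CC(C)N1CCN(Cc2csc(N)c2C(=O)c2ccc(Cl)cc2)CC1` gives 3.6%, compound 2 `Nc1scc(CN2CCN(c3cccnc3)CC2)c1C(=O)c1ccc(Cl)cc1` gives 3.4%, and compound 3 `Nc1scc(CN2CCN(c3ccc(F)cc3F)CC2)c1C(=O)c1ccc(Cl)cc1` gives -17%, the lowest of the three numbers. The step of a number 0.2 percentage points lower from compound 1 to compound 2 (within the scatter) lies within the scatter, whereas a number 20.6 percentage points lower from compound 1 to compound 3 (beyond the scatter) and a number 20.4 percentage points lower from compound 2 to compound 3 (beyond the scatter) both lie beyond it, so compound 3 stands apart from the other two by a modest margin.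

Compound 4 `Nc1scc(CN2CCN(c3ccc(Cl)c(Cl)c3)CC2)c1C(=O)c1ccc(Cl)cc1` has not yet been measured. It differs from compound 3 in one place: 3,4-dichlorophenyl in place of 2,4-difluorophenyl on an amine nitrogen in a ring. The two measured steps that reach compound 3 each bring 2,4-difluorophenyl in for isopropyl or for pyridin-3-yl, and each lowers the number by a modest amount. Going by the values given here, neither exchanges one substituted phenyl for another, so no measured step bears directly on the change from compound 3 to compound 4. The expectation is therefore that the number stays near that of compound 3, with no step beyond the scatter indicated in either direction. For compound 4 the estimate in this assay is -18%, with a range from -40% to 5%. This estimate corresponds to the expected step of a number 1 percentage points lower from compound 3 to compound 4 (within the scatter), which is expected to lie within the scatter.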

Compound 4, a percentage reported as activity, at one concentration (the size of the read-out at that concentration, not a potency): -13%
For compound 4 the middle estimate is 5 percentage points below the measured one, within the range that was stated.
By their numbers in this assay, from the lowest: compounds 3 and 4 (each within the scatter of the next); then compounds 2 and 1 (each within the scatter of the next).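

In this assay, going by these compounds alone, the step of a number 4 percentage points higher from compound 3 to compound 4 (within the scatter) is the first exchange of one substituted phenyl for another on this amine nitrogen, and it stays within the scatter, so these two halogen-bearing phenyl groups cannot be told apart at this position. Within the data shown here, the separation from the other two groups also holds for a second substituted phenyl: the steps of a number 16.4 percentage points lower from compound 2 to compound 4 (beyond the scatter) and a number 16.6 percentage points lower from compound 1 to compound 4 (beyond the scatter) both lie beyond the scatter, so 2,4-difluorophenyl is no longer the only group that stands apart from isopropyl and pyridin-3-yl, and pyridin-3-yl shows that a six-membered aromatic ring on this nitrogen does not by itself go with the lower numbers. No measurement at hand explains why the two halogen-bearing phenyl groups differ from the other two groups.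

The compounds shown leave open whether the lower numbers need halogen on the phenyl, since a plain phenyl, a chlorophenyl or a methoxyphenyl at this nitrogen could fall with either pair. They also leave open how these compounds compare in potency, since each was read at a single concentration.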